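A few compounds are considered here, and "the series" means these few. Any claim that something is new, unique, unknown or untested is made for them only; others in the source may bear on it.

In a functional assay on HeLa cells (Homo sapiens) for antiproliferative activity, read by MTT assay, with a stated time of 24 h (on this read-out lower numbers stand for stronger inhibition and higher numbers for weaker inhibition), compound 1 `c1ccc(CSc2nnc(-c3ccc4c(c3)OCCO4)n2-c2ccccc2)cc1` gives 32800 nM. Compound 2 `COc1cccc(CSc2nnc(-c3ccc4c(c3)OCCO4)n2-c2ccccc2)c1` gives > 100000 nM, which is a limit of the assay and not a number. Going by the values given here, of the two compounds measured so far, compound 2 is therefore the weaker, and the limit of > 100000 nM in this assay, at which 1 of the 2 values shown sits, is all that can be said of its exact standing.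

The next structure is compound 3 `Cc1ccc(CSc2nnc(-c3ccc4c(c3)OCCO4)n2-c2ccccc2)cc1`. The change is 4-methylphenyl in place of 3-methoxyphenyl on a saturated chain carbon bound to a sulfur.

Among the compounds with values here, only one measured step bears on this change: an at least 3.0-fold higher number from compound 1 to compound 2 (0.48 log units; beyond the scatter), with methoxy in place of hydrogen on an aromatic carbon. Compound 3 no longer has that methoxy group, so part or all of that rise may be undone. Within the data shown here, no measured step covers a methyl group, which leaves the outcome uncertain. The number for compound 3 is expected to fall back towards that of compound 1, which gives 32800 nM.

The expected size and direction of the change is an at least 2.5-fold lower number from compound 2 to compound 3 (0.39 log units; beyond the scatter). For compound 3, the estimate is 40000 nM, with an expected range from 14000 nM to 100000 nM.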

Compound 3, half-maximal inhibitory concentration: 49700 nM
Compound 3: the middle estimate sits 1.2-fold (0.09 log units) below what was measured; measured number inside the range.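

Going by these compounds alone, a methyl group in place of hydrogen on an aromatic carbon, a change the earlier compounds did not include, gives a 1.5-fold higher number from compound 1 to compound 3 (0.18 log units; within the scatter), so in this assay this substitution does not separate compound 3 from compound 1. The swap of 3-methoxyphenyl for 4-methylphenyl on the saturated chain carbon bound to a sulfur gives an at least 2.0-fold lower number from compound 2 to compound 3 (0.30 log units; that floor lies within the scatter), which means that even the smallest difference this step allows cannot be told from scatter, although the true gap may be larger. The reading for compound 2 is a limit of the assay and not a number, which is why this step has only a floor: the limit of > 100000 nM in this assay, at which 1 of the 3 values shown sits.

Compound 2 and compound 3 differ both in the group and in where it sits on the ring, so these compounds cannot show whether the methoxy group itself or its placement goes with the weaker result. Going by these compounds, how this position responds to other groups on the ring, such as an amine or a carboxylic acid, also remains open.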